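The source may report more compounds than this note shows. Statements on the series, on what has been measured and on what is new or still open speak of the compounds shown alone.

Compound 1 `Cc1ccc2c(NCc3ccc(NC(=O)C4CCN(Cc5ccc(Cl)cc5)CC4)cc3)nc(N(C)C)nc2c1`: in a functional assay on SV5A8 cells (Homo sapiens) for cytotoxicity (on this read-out lower numbers stand for stronger inhibition and higher numbers for weaker inhibition), compound 1 gives only a limit, > 3180 nM.
Compound 2 `Cc1ccc2c(NCc3ccc(NC(=O)C4CCN(Cc5ccc(F)cc5Cl)CC4)cc3)nc(N(C)C)nc2c1`: in this assay compound 2 gives only a limit, > 5910 nM.
Compound 3 `Cc1ccc2c(NCc3ccc(NC(=O)C4CCN(Cc5cc(Cl)ccn5)CC4)cc3)nc(N(C)C)nc2c1`: in this assay compound 3 gives only a limit, > 5400 nM.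

Compound 3 thus stands at a limit, and the two other values are limits as well, so no order among the three can be read. The steps a step that the two limits leave unreadable from compound 1 to compound 3 and a step that the two limits leave unreadable from compound 2 to compound 3 are unreadable, as is a step that the two limits leave unreadable from compound 1 to compound 2. Each compound sits at its own limit: the limit of > 3180 nM in this assay, at which 1 of the 3 values shown sits, (the limit of > 5910 nM in this assay, at which 1 of the 3 values shown sits), (the limit of > 5400 nM in this assay, at which 1 of the 3 values shown sits).

Compound 4 `Cc1ccc2c(NCc3ccc(NC(=O)C4CCN(CC5CCNCC5)CC4)cc3)nc(N(C)C)nc2c1` differs from compound 3 by piperidin-4-yl in place of 4-chloropyridin-2-yl on a saturated chain carbon bound to an amine nitrogen in a ring. Within the data shown here, none of the measured steps concerns a change from an aromatic ring to a saturated one at this position, and all three are unreadable anyway, so no size of step can be derived from them.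

Compound 4 is expected to remain at a limit in this assay, with an estimated value of 6000 nM and a range from 2000 nM to 20000 nM. The step that the limit leaves unreadable from compound 3 to compound 4 is therefore expected to show nothing readable beyond the scatter.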

Compound 4, half-maximal inhibitory concentration: > 8070 nM
Compound 4: only a limit was reported; the forecaster's own chance of this, stated with the estimate: 80%; middle value at least 1.3-fold (0.12 log units) away from the limit.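

In this assay compound 4 gives only a limit, > 8070 nM. Among these compounds, compound 1, compound 2 and compound 3 also stand at limits, so no step to compound 4 can be read. The compounds shown leave open whether piperidin-4-yl or any of the aromatic groups at this place shifts the value at all.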